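Cytotoxicity notes on a quinoline-free phrased series of carbamoyl hydrazides

The source may report more compounds than this note shows. Statements on the series, on what has been measured and on what is new or still open speak of the compounds shown alone.

Measured so far:
compound 1, `COc1cc(NC(C)CCCNC(=O)NNC(=O)/C=C/c2ccc(Cl)cc2)c2ncccc2c1`: 7300 nM
compound 2, `COc1cc(NC(C)CCCNC(=O)NNC(=O)NCCCO)c2ncccc2c1`: "not determined" (no result reported)

In an ADME assay on L6 cells (Rattus norvegicus) for cytotoxicity, read by resazurin assay, with a stated time of 70 h (on this read-out higher numbers stand for weaker inhibition and lower numbers for stronger inhibition), compound 1 gives 7300 nM. Among the compounds with values here, compound 2 has no single number in this assay, so its standing cannot be placed against compound 1, and the pair shows only that one value exists and the other does not.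

Compound 3, `COc1cc(NC(C)CCCNC(=O)NNC(=O)Nc2cccc(C(F)(F)F)c2)c2ncccc2c1`, differs from compound 2 in one place: 3-(trifluoromethyl)phenyl in place of 3-hydroxypropyl on an amide-type nitrogen. With no measured step of this kind in the series, the size and direction of the change in this assay cannot be set from the data; any step of a size within the usual scatter or beyond it remains open.

Within the data shown here, for compound 3 the value in this assay is estimated at 10000 nM, expected between 2000 nM and 60000 nM, taking the one available reading, that of compound 1 at 7300 nM, as the only anchor.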

Compound 3, half-maximal inhibitory concentration: 32100 nM
Compound 3: the middle estimate sits 3.2-fold (0.51 log units) below what was measured; the measured number falls inside the stated range.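

In this assay the group on the carbonyl carbon proves able to move this read-out: (3-(trifluoromethyl)phenyl)amino in place of 2-(4-chlorophenyl)ethenyl gives a 4.4-fold higher number from compound 1 to compound 3 (0.64 log units; beyond the scatter), a modest shift towards weaker inhibition of L6 cells. Within the data shown here, this is the first step that can be read, and it shows that an aromatic ring reached through an amino link on that carbon is compatible with a higher number on the shared core. Nothing on hand bears on the reason for this shift.

As far as these compounds go, the step from compound 2 to compound 3 cannot be read, as compound 2 has no number, so the contribution of 3-hydroxypropyl stays unknown. From the compounds shown here alone, how an amine, a carboxylic acid or a longer chain on the amide-type nitrogen would read in this cell assay also remains open.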